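Piperidinyl for trifluorobutoxy on the shared core

The source may hold more compounds than are shown below. What is called first, only, known or untested is meant among the compounds shown, and "the series" means these compounds.

Measured so far:
compound 1 `CN(Cc1cc(C(F)(F)F)cc(C(F)(F)F)c1)C(=O)c1c(OCCCC(F)(F)F)c2ccccc2n(C)c1=O`: 120 nM
compound 2 `CN(Cc1cc(C(F)(F)F)cc(C(F)(F)F)c1)C(=O)c1c(OCCCC2CCN(C(=O)OC3(C)CC3)CC2)c2cccnc2n(C)c1=O`: 47 nM

In an assay on cells for inhibition of phosphatidylcholine:ceramide cholinephosphotransferase 2 (Homo sapiens), read by mass spectrometry, with stated times of 60 min and 30 min (a lower number here means a stronger inhibitor, a higher number a weaker inhibitor), compound 1 gives 120 nM, the highest of the two numbers at hand. Among the compounds with values here, compound 2, the nearest comparator, gives 47 nM in this assay, a lower number than compound 1 and beyond the usual scatter; the two structures differ in more than one place, so no single step can be drawn between them.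

Compound 3 `CN(Cc1cc(C(F)(F)F)cc(C(F)(F)F)c1)C(=O)c1c(N2CCCCC2)c2ccccc2n(C)c1=O` is the next candidate. Relative to compound 1 it carries piperidin-1-yl in place of 4,4,4-trifluorobutoxy on an aromatic carbon. Within the data shown here, no measured pair shows this exchange, so there is no precedent for its size or direction.

With nothing comparable on hand, the step from compound 1 to compound 3 is expected to be small and, if anything, toward a higher number: a 1.7-fold higher number from compound 1 to compound 3 (0.22 log units; within the scatter) is the estimate. Compound 3 is therefore expected to give about 200 nM in this assay, within a range of 60 nM to 700 nM.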

Compound 3, half-maximal inhibitory concentration: 11000 nM
Estimate against measurement, compound 3: 55-fold (1.74 log units) below; the measured number lies above the stated range.
By their numbers in this assay, from the lowest: compound 2; then compound 1; then compound 3.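

In this assay, the step of a 92-fold higher number from compound 1 to compound 3 (1.96 log units; beyond the scatter) shows that this aromatic carbon, opposite the ring nitrogen, does not accept every group of similar size: piperidin-1-yl in place of 4,4,4-trifluorobutoxy costs far more than the scatter. Counted features do not separate the two groups, since the leaving and entering groups match in hydrogen-bond donors, hydrogen-bond acceptors and net charge; they differ in the attached atom, oxygen against nitrogen, and in the presence of a ring. No measurement on hand bears on the reason for this large step.

The compounds shown leave open whether the step follows from the attachment through nitrogen or from the ring itself; a 4,4,4-trifluorobutylamino chain, with a secondary amine at the same carbon, and a piperidin-4-yloxy group, with the ring held on oxygen, would pull these two apart. Also open, going by these compounds, is whether piperidin-1-yl at this carbon has the same consequence on the core of compound 2, which differs from compound 1 in more than one place.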